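Replacing a Triple Bond in a Urotensin Receptor Agonist Series

The compounds below may be only part of what the source reports. "The series", "measured", "known", "first", "only" and "open" are said of these compounds alone.

Measured compounds:
compound 1 `Cc1ccc(C(CCN(C)C)NC(=O)CCc2ccccc2)cc1` gives 73%
compound 2 `CN(C)CCC(NC(=O)C#Cc1ccccc1)c1ccc(Cl)cc1` gives 124%

In a functional assay on NIH3T3 cells for agonist activity at Urotensin-2 receptor (Homo sapiens), with a stated time of 5 days (a lower number here means a smaller maximal response, a higher number a larger maximal response), compound 2 stands highest of the two numbers; compound 1 is the nearest and lies well beyond the scatter below it. Compound 3 `CN(C)CCC(NC(=O)CCc1ccccc1)c1ccc(Cl)cc1` has not been measured. It differs from compound 2 in one place: phenethyl in place of 2-phenylethynyl on a carbonyl carbon. Compound 1 also carries a phenethyl on its carbonyl carbon and gives the lower value, so a downward step beyond the scatter is expected, a number 39 percentage points lower from compound 2 to compound 3 (beyond the scatter). Compound 3 is estimated at 85%, expected between 60% and 115%.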

Compound 3, largest response reached (reported as efficacy), in percent of the reference or control that the assay uses: 139%
Beside the measured number, compound 3's estimate is 54 percentage points below it; the whole stated range lies below it.
By their numbers in this assay, from the lowest: compound 1; then compound 2; then compound 3.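

In this assay, a triple bond at this position is not required for a large maximal response: phenethyl in place of 2-phenylethynyl on a carbonyl carbon gives a number 15 percentage points higher from compound 2 to compound 3 (beyond the scatter). With phenethyl held constant, the aromatic substituent also matters, as chloro in place of methyl on an aromatic carbon gives a number 66 percentage points higher from compound 1 to compound 3 (beyond the scatter). Nothing available explains the cause of either step. Going by these compounds, whether a longer chain, such as 3-phenylpropyl, would keep this response remains open. So does the effect of a fluoro or methoxy group in place of chloro.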